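Removing one hydroxymethyl group from compound 3

The source may hold more compounds than are shown below. What is called first, only, known or untested is meant among the compounds shown, and "the series" means these compounds.

Three compounds share one core and differ in the group at the end of their side chain. In a functional assay on A-375 cells (Homo sapiens) for cytotoxicity, read by MTT assay, with a stated time of 72 h (on this read-out higher numbers stand for weaker inhibition and lower numbers for stronger inhibition), compound 1 (`O=C1c2c[n+]([O-])c3ccccc3c2C(=O)c2c1c1ccccc1n2Cc1cn([C@H]2O[C@H](CO)[C@@H](O)[C@H]2O)nn1`) gives 340 nM, compound 2 (`O=C1c2c[n+]([O-])c3ccccc3c2C(=O)c2c1c1ccccc1n2Cc1cn(CC(O)CO)nn1`) gives 440 nM and compound 3 (`CC1(C)O[C@@H](CO)[C@H](Cn2cc(Cn3c4c(c5ccccc53)C(=O)c3c[n+]([O-])c5ccccc5c3C4=O)nn2)O1`) gives 190 nM. Compound 3 sits at the low end of this small set, but the gap to its nearest neighbour is small: a 1.8-fold lower number from compound 1 to compound 3 (0.25 log units; within the scatter). The one clear gap is a 2.3-fold lower number from compound 2 to compound 3 (0.36 log units; beyond the scatter).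

Compound 4 (`CC1(C)OC[C@H](Cn2cc(Cn3c4c(c5ccccc53)C(=O)c3c[n+]([O-])c5ccccc5c3C4=O)nn2)O1`) alters compound 3 in a single place, with hydrogen in place of hydroxymethyl on a saturated ring carbon. Among the compounds with values here, no measured pair isolates this change, so the evidence is indirect. The remaining measured step, a 1.3-fold higher number from compound 1 to compound 2 (0.11 log units; within the scatter), is also small, and the modest 2.3-fold lower number from compound 2 to compound 3 (0.36 log units; beyond the scatter) is the largest shift seen so far among these end groups. Exchanges at this end of the molecule have therefore moved the number only slightly in this assay, and a similar outcome is expected here. The expected step is a 1.2-fold higher number from compound 3 to compound 4 (0.06 log units; within the scatter), which means no shift beyond the scatter and no firm direction. For compound 4 the estimated value is 220 nM, with an expected range from 100 nM to 480 nM.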

Compound 4, half-maximal inhibitory concentration: 180 nM
The estimate for compound 4 lay 1.2-fold (0.09 log units) above the measured number; the measured number falls inside the stated range.
By their numbers in this assay, from the lowest: compounds 4, 3, 1 and 2 (each within the scatter of the next, the first and the last beyond it).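

Within the data shown here, compound 4 gives the first direct reading at this position: in this assay, removing the hydroxymethyl group from a saturated ring carbon of the five-membered ring with 2 oxygen gives a 1.1-fold lower number from compound 3 to compound 4 (0.02 log units; within the scatter) and so leaves the number unchanged within the scatter, which means this group, with its one hydrogen-bond donor and one hydrogen-bond acceptor, is not required for the activity seen here. The ring without it also keeps the clear gap to the 1,2-dihydroxyethyl end group, with a 2.4-fold lower number from compound 2 to compound 4 (0.39 log units; beyond the scatter) as the step, while a 1.9-fold lower number from compound 1 to compound 4 (0.28 log units; within the scatter) stays within the scatter, so the ring shows no firm difference from the 3,4-dihydroxy-5-(hydroxymethyl)oxolan-2-yl end group. Nothing available on these compounds gives a reason for this outcome.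

The compounds shown leave open whether this ring carbon would tolerate a different kind of group, since an amine, a carboxylic acid or a longer chain such as hydroxyethyl in place of the hydroxymethyl group could still move the number. Equally open, as far as these compounds go, is what ethyl groups in place of the two methyl groups on the ring would do.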